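Amide substituent swap in the spiro-series: compound 1 to 4

The source may report more compounds than this note shows. Statements on the series, on what has been measured and on what is new or still open speak of the compounds shown alone.

Measured so far:
- compound 1, `CC(C)(C)OC(=O)NCCNC(=O)CN1CN(c2ccccc2)C2(CCN(C(=O)c3ccc(C(C)(C)C)cc3)CC2)C1=O`: 10900 nM
- compound 2, `CC(C)(C)OC(=O)NCC1CCCN(C(=O)CN2CN(c3ccccc3)C3(CCN(C(=O)c4ccc(C5CCCCC5)cc4)CC3)C2=O)C1`: 3800 nM
- compound 3, `CCC1CCCN(C(=O)CN2CN(c3ccccc3)C3(CCN(C(=O)c4ccc(C5CCCCC5)cc4)CC3)C2=O)C1`: 2600 nM

All three numbers come from an assay on HEK293 cells for displacement of a labelled ligand from NPC1-like intracellular cholesterol transporter 1 (Homo sapiens); a higher number here means a weaker inhibitor, a lower number a stronger inhibitor. In this assay compound 1 gives 10900 nM, the highest of the three numbers; compound 2 and compound 3 both sit beyond the scatter below it. Among the compounds with values here, the only single-point step among the measured compounds is a 1.5-fold lower number from compound 2 to compound 3 (0.16 log units; within the scatter), which shows that trading the (tert-butoxycarbonyl)amino group for a methyl on the piperidine-bearing chain changes little.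

The new compound 4, `CC(C)(C)c1ccc(C(=O)N2CCC3(CC2)C(=O)N(CC(=O)N2CCCC(O)C2)CN3c2ccccc2)cc1`, differs from compound 1 at the acetamide: 3-hydroxypiperidin-1-yl in place of (2-((tert-butoxycarbonyl)amino)ethyl)amino on a carbonyl carbon. Within the data shown here, no measured pair shares exactly this change, since compound 2 and compound 3 carry a ring amide together with a different aryl substituent, so their numbers cannot be split into the two contributions. The step of a 1.5-fold lower number from compound 2 to compound 3 (0.16 log units; within the scatter) bears on it only indirectly, suggesting that the (tert-butoxycarbonyl)amino portion is not what holds compound 1 at its number.

Expectation: a modest move toward a lower number, at most of the order seen between compound 1 and compound 2, but with wide uncertainty; the step expected is a 2.0-fold lower number from compound 1 to compound 4 (0.30 log units; within the scatter). Compound 4 is estimated at 5500 nM (range 1800 nM to 16000 nM).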

Compound 4, half-maximal inhibitory concentration: 12200 nM
For compound 4 the middle estimate is 2.2-fold (0.35 log units) below the measured one; the range from low to high includes it.
By their numbers in this assay, from the lowest: compounds 3 and 2 (each within the scatter of the next); then compounds 1 and 4 (each within the scatter of the next).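

In this assay, within the data shown here, 3-hydroxypiperidin-1-yl in place of (2-((tert-butoxycarbonyl)amino)ethyl)amino on a carbonyl carbon gives a 1.1-fold higher number from compound 1 to compound 4 (0.05 log units; within the scatter), the first reading of a single-place change at this position. With the tert-butyl group held fixed, compound 4 keeps no (tert-butoxycarbonyl)amino portion and no open chain at this carbonyl carbon, yet its number stays within the scatter of compound 1, so for this pair neither feature is needed to hold that level. No measured evidence gives a reason for this lack of movement.

From the compounds shown here alone, how much of the separation of compound 1 and compound 4 from compound 2 and compound 3 belongs to the tert-butyl against the cyclohexyl group, and how much to the amide substituent, stays open, as these compounds differ in more than one place. Also open, going by these compounds, is whether a carboxylic acid, a primary amine or a longer chain on this carbonyl carbon would move the number beyond the scatter, or whether the position stays as flat as this single pair suggests.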